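Oxygen-side group change from compound 3 to compound 4

This account rests on a few compounds, and the source may have more. Where it says the series, first, only, none or still open, it means among the compounds named here.

Compound 1 `CCN(C(=O)OC)c1c(N)nc(-c2nn(Cc3ccccc3F)c3ncccc23)nc1N` gives 0.2 uM in an assay on cells for activation of Guanylate cyclase soluble subunit alpha-1 (Rattus norvegicus), read by cGMP accumulation and immunoassay, with a stated time of 10 min; a lower number here means that less compound is needed, a higher number that more compound is needed for the effect. Compound 2 `COC(=O)N(CCO)c1c(N)nc(-c2nn(Cc3ccccc3F)c3ncccc23)nc1N` gives 0.3 uM and compound 3 `Nc1nc(-c2nn(Cc3ccccc3F)c3ncccc23)nc(N)c1NC(=O)OC1CCC1` gives 0.2 uM. The three measured steps are all small: a 1.5-fold higher number from compound 1 to compound 2 (0.18 log units; within the scatter), no change at the digits printed from compound 1 to compound 3 (within the scatter) and a 1.5-fold lower number from compound 2 to compound 3 (0.18 log units; within the scatter). Compound 3 is level with compound 1 at the digits shown, and together they carry the lowest numbers of the three, with compound 2 within the scatter of both.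

Compound 4 `Nc1nc(-c2nn(Cc3ccccc3F)c3ncccc23)nc(N)c1NC(=O)OCC(F)(F)F` differs from compound 3 by 2,2,2-trifluoroethyl in place of cyclobutyl on an oxygen next to a carbonyl group. For the measured compounds named here, no measured step alters the group on the oxygen next to the carbonyl while leaving the rest untouched; the nearest comparisons are the exchanges of the whole substituent on the aromatic carbon, from compound 1 and from compound 2 to compound 3, both within the scatter. As far as these compounds go, that the methoxycarbonyl of compound 1 and the cyclobutyloxycarbonyl of compound 3 read the same suggests this position tolerates variation, so for compound 4 no step beyond the scatter is expected, no change at the digits printed from compound 3 to compound 4 (within the scatter), with a wide range since the change is untested. Compound 4 is estimated at 0.2 uM, between 0.1 uM and 0.5 uM, in this assay.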

Compound 4, minimum effective concentration: 0.2 uM
Beside the measured number, compound 4's estimate shows no gap at the digits printed; measured number inside the range.
By their numbers in this assay, from the lowest: compounds 1, 3, 4 and 2 (each within the scatter of the next).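

In this assay, the exchange on the oxygen next to a carbonyl group gives no change at the digits printed from compound 3 to compound 4 (within the scatter) and is the only step shown that alters this group while leaving the rest of the molecule untouched. For this pair, the four-membered carbon ring of cyclobutyl is not needed to hold the number, and 2,2,2-trifluoroethyl, which has no ring and carries fluorine, reads the same at the digits printed. The whole-substituent comparisons agree, with no change at the digits printed from compound 1 to compound 4 (within the scatter) and a 1.5-fold lower number from compound 2 to compound 4 (0.18 log units; within the scatter) both read against the new compound, so this assay separates none of the four compounds shown.

As far as these compounds go, whether the same oxygen also accepts a group bearing an amine or a carboxylic acid, or a longer chain such as n-hexyl, remains open, as does whether any such group would give a step beyond the scatter. No measurement shown bears on why cyclobutyl and 2,2,2-trifluoroethyl read alike.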